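A bromo analogue after the dichloro drop

The source may report more compounds than this note shows. Statements on the series, on what has been measured and on what is new or still open speak of the compounds shown alone.

Measured so far:
compound 1 `O=C(Nc1ccc(Cl)cc1)NS(=O)(=O)c1cc2ccccc2o1`: 84%
compound 2 `O=C(Nc1ccc(Cl)cc1)NS(=O)(=O)c1cccc2occc12`: 84%
compound 3 `O=C(Nc1ccc(Cl)c(Cl)c1)NS(=O)(=O)c1cc2ccccc2o1`: 28%

In a functional assay on the whole organism (Mus musculus) for inhibition, at a dose of 150 mg/kg by the oral route (a higher number here means more inhibition at the dose given (going by the name of the read-out), a lower number less inhibition), compound 3 stands lowest of the three; compound 1 gives 84% and compound 2 gives 84%, both far above it. For the measured compounds named here, the only measured step that bears on the next compound is the one from compound 1 to compound 3, a number 56 percentage points lower from compound 1 to compound 3 (beyond the scatter). Compound 4 `O=C(Nc1ccc(Br)cc1)NS(=O)(=O)c1cc2ccccc2o1` takes the path back: 4-bromophenyl in place of 3,4-dichlorophenyl on an amide-type nitrogen. Going by the values given here, the 3,4-dichlorophenyl that went with that large drop leaves, and a ring carrying a single halogen enters, though bromine rather than chlorine, a swap for which no measured pair exists. For compound 4 a rise beyond the scatter is therefore expected, a number 47 percentage points higher from compound 3 to compound 4 (beyond the scatter), bringing it toward the level of compound 1. The estimate for compound 4 is 75%, between 45% and 95%.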

Compound 4, a percentage reported as inhibition, in the whole organism at one dose (the size of the read-out at that dose, not a potency): 48%
For compound 4 the middle estimate is 27 percentage points above the measured one, within the range that was stated.
By their numbers in this assay, from the lowest: compound 3; then compound 4; then compounds 1 and 2 (each within the scatter of the next).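

Only part of the loss returns in this assay, with a number 20 percentage points higher from compound 3 to compound 4 (beyond the scatter) when 4-bromophenyl takes the place of 3,4-dichlorophenyl on the amide-type nitrogen. The single halogen itself also counts here, since bromo in place of chloro on an aromatic carbon gives a number 36 percentage points lower from compound 1 to compound 4 (beyond the scatter) on its own. No measurement bears on why the two halogens differ. Still open, on these data alone, is how a methyl or methoxy group would fare in that place, and whether the bromo swap would give the same drop on the core of compound 2.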